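This account rests on a few compounds, and the source may have more. Where it says the series, first, only, none or still open, it means among the compounds named here.

Working notes on the series in an in vivo ADME assay on the whole organism (strain Sprague-Dawley) for pharmacokinetics, with Rattus norvegicus as the target; on this read-out lower numbers stand for narrower distribution and higher numbers for wider distribution into tissues

- Compound 1 `CN[C@@H](C)c1ccc(N2CC[C@H](NS(=O)(=O)c3ccc4cc(Cl)ccc4c3)C2=O)c(F)c1`: 2.4 L/kg
- Compound 2 `CN(C)C1CCc2cc(N3CC[C@H](NS(=O)(=O)/C=C/c4ccc(Cl)s4)C3=O)ccc21`: 1.1 L/kg

Compound 1 stands highest of the two, and compound 2 lies lower by more than the scatter. Compound 3 `O=C1[C@@H](NS(=O)(=O)c2ccc3cc(Cl)ccc3c2)CCN1c1ccc(C2CCCN2)cc1F` is not yet measured. It carries pyrrolidin-2-yl in place of 1-(methylamino)ethyl on an aromatic carbon of the core of compound 1 pyrrolidin-2-yl in place of 1-(methylamino)ethyl on an aromatic carbon and is otherwise unchanged. Going by the values given here, no measured step covers this change, so no shift beyond the scatter is expected in this assay here. An estimated 1.1-fold lower number from compound 1 to compound 3 (0.04 log units; within the scatter) would lie within the scatter. The estimate for compound 3 is 2.2 L/kg and the expected range runs from 1.1 L/kg to 4.5 L/kg for this compound.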

Compound 3, volume of distribution at steady state: 1.9 L/kg
Compound 3: middle estimate off by 1.2-fold (0.06 log units), on the high side, and the stated range covers the measured number.
By their numbers in this assay, from the lowest: compounds 2, 3 and 1 (each within the scatter of the next, the first and the last beyond it).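

In this assay, going by these compounds alone, pyrrolidin-2-yl in place of 1-(methylamino)ethyl on this aromatic carbon, meta to a fluoro group, gives the first measured step at this position (a 1.3-fold lower number from compound 1 to compound 3 (0.10 log units; within the scatter)). A five-membered non-aromatic ring is therefore accepted here without a shift beyond the scatter. The leaving group has a defined stereocentre and the entering group has none, so this step does not separate the two stereo forms of the ring.

Going by these compounds, whether piperidin-2-yl or a carboxylic acid at this carbon would stay within the scatter remains open. Nothing available explains the size of this step.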